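Chloro in Place of Nitro: What Compound 4 Might Show

This account rests on a few compounds, and the source may have more. Where it says the series, first, only, none or still open, it means among the compounds named here.

Measured compounds:
compound 1 `O=Cc1cn(-c2ccccc2)nc1-c1cccc([N+](=O)[O-])c1` — 75%
compound 2 `O=Cc1cn(-c2ccccc2)nc1-c1ccc(Cl)cc1` — 59%
compound 3 `COc1cc(/C=C/C(=O)C(=Cc2cn(-c3ccccc3)nc2-c2ccc([N+](=O)[O-])cc2)C(=O)/C=C/c2ccc(O)c(OC)c2)ccc1O` — 90%

In a functional assay on MCF7 cells (Homo sapiens) for antiproliferative activity, read by MTT assay, with a stated time of 24 h, tested at 1 ug/mL (a higher number here means a weaker effect of the compound at the concentration tested, a lower number a stronger effect), compound 3 stands highest of the three numbers, with the nearest, compound 1, a number beyond the scatter below it and compound 2 further below still. Compound 4 `COc1cc(/C=C/C(=O)C(=Cc2cn(-c3ccccc3)nc2-c2ccc(Cl)cc2)C(=O)/C=C/c2ccc(O)c(OC)c2)ccc1O` differs from compound 3 in one place: chloro in place of nitro on an aromatic carbon. Among the smaller compounds, compound 2, which carries chloro, gives 59%, whereas compound 1 gives 75%; these two differ in more than that one place, so they show only what their values show. For compound 4 a modest downward step is expected, a number 10 percentage points lower from compound 3 to compound 4 (within the scatter), not confidently beyond the scatter. Compound 4 is estimated at 80%, with a range from 62% to 96%.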

Compound 4, a percentage reported as activity, at one concentration (the size of the read-out at that concentration, not a potency): 65%
Estimate against measurement, compound 4: 15 percentage points above; measured number inside the range.
By their numbers in this assay, from the lowest: compounds 2, 4 and 1 (each within the scatter of the next, the first and the last beyond it); then compound 3.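

In this assay, within the data shown here, chloro in place of nitro on the aromatic carbon gives a number 25 percentage points lower from compound 3 to compound 4 (beyond the scatter), the first step here that can be read across a single place. The two compounds differ in nothing else, so a stronger effect at the concentration tested goes with this change alone, which compound 1 and compound 2 could not show, as they differ in more than that place. Nothing given here accounts for the step. Going by these compounds, whether other groups at this place, such as an amine or a carboxylic acid, would move the number further remains open. So does whether the same change would give a similar step on the smaller compounds.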